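Aryl swap on the enone chain: cytotoxicity notes

The source may hold more compounds than are shown below. What is called first, only, known or untested is meant among the compounds shown, and "the series" means these compounds.

Three compounds share one core and differ only in the aryl group at the end of the enone chain. In an ADME assay on the whole organism for cytotoxicity, with Artemia salina as the target, with a stated time of 24 h (a higher number here means that more compound is needed for the effect, a lower number that less compound is needed), compound 1 `COc1cccc(/C=C/C(=O)c2ccccc2NC(=O)NS(=O)(=O)c2ccc(C)cc2)c1` gives 23.2 ug/mL, compound 2 `COc1ccc(/C=C/C(=O)c2ccccc2NC(=O)NS(=O)(=O)c2ccc(C)cc2)c(OC)c1` gives 16 ug/mL, and compound 3 `Cc1ccc(S(=O)(=O)NC(=O)Nc2ccccc2C(=O)/C=C/c2ccccc2[N+](=O)[O-])cc1` gives 40.1 ug/mL. Compound 2 has the lowest of the three numbers; the nearest step is a 1.5-fold lower number from compound 1 to compound 2 (0.16 log units; within the scatter), the furthest is a 2.5-fold higher number from compound 2 to compound 3 (0.40 log units; beyond the scatter). The remaining pair, a 1.7-fold higher number from compound 1 to compound 3 (0.24 log units; within the scatter), also stays within the scatter.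

Compound 4 `Cc1ccc(S(=O)(=O)NC(=O)Nc2ccccc2C(=O)/C=C/c2ccc(F)cc2)cc1` is not yet measured. Its change from compound 2: 4-fluorophenyl in place of 2,4-dimethoxyphenyl on a double-bonded chain carbon bound to a double-bonded chain carbon

Every measured step swaps one aryl group for another at the same place on the chain, so all three bear on this one. Only one of them, the step between compound 2 and compound 3, went beyond the scatter, and modestly; the other two did not. An aryl swap therefore moves the number in this assay only a little. Compound 2 sits at the low end of the set, so for compound 4 a small upward step, or none beyond the scatter, is expected, a 1.4-fold higher number from compound 2 to compound 4 (0.14 log units; within the scatter). Compound 4 is estimated at 22 ug/mL, with a range from 12 ug/mL to 45 ug/mL.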

Compound 4, concentration for half-maximal effect: 3.96 ug/mL
The estimate for compound 4 lay 5.6-fold (0.74 log units) above the measured number; the whole stated range lies above it.
By their numbers in this assay, from the lowest: compound 4; then compounds 2, 1 and 3 (each within the scatter of the next, the first and the last beyond it).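

In this assay, among these compounds, the aryl group at this place on the chain can move the number much further than the earlier compounds showed: 4-fluorophenyl in place of 2,4-dimethoxyphenyl gives a 4.0-fold lower number from compound 2 to compound 4 (0.61 log units; beyond the scatter), in place of 3-methoxyphenyl it gives a 5.9-fold lower number from compound 1 to compound 4 (0.77 log units; beyond the scatter), and in place of 2-nitrophenyl it gives a 10-fold lower number from compound 3 to compound 4 (1.01 log units; beyond the scatter), the only large step in the set. All three steps lie beyond the scatter, so a position that looked nearly flat among the methoxy and nitro aryl groups sets compound 4 apart from every other compound shown, with the lowest number of the four. Compared with 2,4-dimethoxyphenyl, the entering 4-fluorophenyl has fewer heavy atoms and no hydrogen-bond acceptors, but no measurement at hand explains the lower number.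

Among the compounds shown here, with only one fluorine-bearing aryl group in the set, the role of the fluorine cannot be separated from the loss of the methoxy or nitro groups; unsubstituted phenyl and 4-chlorophenyl would be the informative comparisons. Going by these compounds, it also stays open whether the lower number would persist with an amine or a carboxylic acid on the aryl group at this place.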